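This account rests on a few compounds, and the source may have more. Where it says the series, first, only, none or still open, it means among the compounds named here.

Working notes on the series. Compound 1 `CC#C[C@@H](Cc1nnn[nH]1)c1ccc(OCc2ccc3scc(-c4ccccc4C(F)(F)F)c3c2)cc1`, compound 2 `CC#C[C@@H](Cc1nnn[nH]1)c1ccc(OCc2ccc3scc(-c4ccc(OCCOC)cc4C)c3c2)cc1` and compound 3 `CC#C[C@@H](Cc1nnn[nH]1)c1ccc(OCc2ccc3sc(C(F)(F)F)c(-c4ccc(OCCOC)cc4C)c3c2)cc1` share one core and differ only at the aryl group and its neighbouring ring position. In an ADME assay on microsomes from liver (Homo sapiens) for metabolic stability (a lower number here means that the compound disappears faster, a higher number that the compound lasts longer), compound 1 gives only a limit, < 0.0667 h, which is the limit of < 0.0667 h in this assay, at which 1 of the 3 values shown sits. For the measured compounds named here, compound 2 gives 0.717 h in this assay, the only plain number among the three. Compound 3 again gives only a limit in this assay, > 3 h, which is the limit of > 3 h in this assay, at which 1 of the 3 values shown sits. The two measured steps, an at least 10-fold higher number from compound 1 to compound 2 (1.03 log units; beyond the scatter) and an at least 4.1-fold higher number from compound 2 to compound 3 (0.62 log units; beyond the scatter), both lifted the half-life well beyond the scatter.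

Compound 4 `CC#C[C@@H](Cc1nnn[nH]1)c1ccc(OCc2ccc3scc(-c4ccc(OCCC(C)(C)O)cc4C)c3c2)cc1` departs from compound 2 by 1-hydroxy-1-methylethyl in place of methoxy on a saturated chain carbon, two bonds along the chain from an oxygen on an aromatic ring. Neither measured step touched this chain, so they bear only indirectly on the change; both show the half-life in this assay responding strongly to substitution on the aryl side. The step from compound 2 to compound 4 is expected to be modest, a 1.7-fold higher number from compound 2 to compound 4 (0.22 log units; within the scatter), tending upward rather than downward. Compound 4 is therefore estimated at 1.2 h in this assay, within 0.5 h to 3 h.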

Compound 4, half-life: 0.95 h
Compound 4: the middle estimate sits 1.3-fold (0.10 log units) above what was measured; the measured number falls inside the stated range.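

In this assay, 1-hydroxy-1-methylethyl in place of methoxy on a saturated chain carbon, two bonds along the chain from an oxygen on an aromatic ring, gives a 1.3-fold higher number from compound 2 to compound 4 (0.12 log units; within the scatter), so the two compounds cannot be told apart on half-life. Unlike the earlier changes to the aryl group and its neighbouring ring position, both of which moved the half-life beyond the scatter, this exchange at the chain end leaves no readable change, even though the entering group carries a hydrogen-bond donor that methoxy lacks. Nothing measured in the series bears on why this exchange leaves the half-life unresolved. From the compounds shown here alone, whether the same holds for an amine, a carboxylic acid or a longer chain at this position remains open. Also open, going by these compounds, is how 3-hydroxy-3-methylbutoxy behaves when combined with the trifluoromethyl group present in compound 3.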